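The source may report more compounds than this note shows. Statements on the series, on what has been measured and on what is new or still open speak of the compounds shown alone.

Measured compounds:
compound 1 `O=C(/C=C/c1cccc(NS(=O)(=O)c2cccc(Cl)c2)c1)c1nc2ccccc2[nH]1`, 4160 nM
compound 2 `Cc1ccccc1S(=O)(=O)Nc1cccc(/C=C/C(=O)c2nc3ccccc3[nH]2)c1`, 4130 nM
compound 3 `Cc1cccc(S(=O)(=O)Nc2cccc(/C=C/C(=O)c3nc4ccccc4[nH]3)c2)c1`, 886 nM

In a functional assay on MCF7 cells (Homo sapiens) for antiproliferative activity, read by MTT assay, with a stated time of 48 h (on this read-out higher numbers stand for weaker inhibition and lower numbers for stronger inhibition), compound 3 stands lowest of the three: the step of a 4.7-fold lower number from compound 1 to compound 3 (0.67 log units; beyond the scatter) and the step of a 4.7-fold lower number from compound 2 to compound 3 (0.67 log units; beyond the scatter) both lie beyond the scatter, while the step of a 1.0-fold lower number from compound 1 to compound 2 (0.00 log units; within the scatter) does not. Compound 4 `O=C(/C=C/c1cccc(NS(=O)(=O)c2cc(Cl)cc(Cl)c2)c1)c1nc2ccccc2[nH]1` has not yet been measured. It differs from compound 3 in one place: 3,5-dichlorophenyl in place of 3-methylphenyl on a sulfonyl sulfur. Among the measured compounds shown here, two measured steps bear on this change. The step from compound 1 to compound 3 exchanged chloro for methyl on the aromatic carbon and gave a modest lowering; compound 4 reverses that exchange and carries a second chloro on the same ring. For the measured compounds named here, no measured pair shows what the second chloro does. The nearest measured reference is therefore compound 1, and compound 4 is expected to land close to it, so that a modest rise back from compound 3 is estimated, a 4.0-fold higher number from compound 3 to compound 4 (0.60 log units; beyond the scatter). For compound 4 the estimate in this assay is 3500 nM, with a range from 1200 nM to 10000 nM.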

Compound 4, half-maximal inhibitory concentration: 20000 nM
The estimate for compound 4 lay 5.7-fold (0.76 log units) below the measured number; measured number outside the range, above it.
By their numbers in this assay, from the lowest: compound 3; then compounds 2 and 1 (each within the scatter of the next); then compound 4.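

In this assay, adding a second chloro to the ring on the sulfonyl sulfur proved costly, and replacing hydrogen with chloro gives a 4.8-fold higher number from compound 1 to compound 4 (0.68 log units; beyond the scatter) as the first measured effect of this kind. The 3,5-dichlorophenyl group also stands behind both methyl-bearing rings, giving a 4.8-fold higher number from compound 2 to compound 4 (0.69 log units; beyond the scatter) in a modest step and a 23-fold higher number from compound 3 to compound 4 (1.35 log units; beyond the scatter) in a large one, so the group on the sulfonyl sulfur can weaken the read-out well beyond what the single chloro showed. No evidence here bears on the cause of this loss. On these data alone, it remains open whether the loss belongs to the added chloro itself or to the 3,5-dichlorophenyl group as a whole. As far as these compounds go, how a ring carrying a methoxy group or an amine would stand on this sulfonyl sulfur also remains open.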